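The source may report more compounds than this note shows. Statements on the series, on what has been measured and on what is new or still open speak of the compounds shown alone.

Measured in a functional assay on NCI-H1975 cells (Homo sapiens) for antiproliferative activity, read by MTT assay, with a stated time of 72 h; a lower number here means a stronger inhibitor, a higher number a weaker inhibitor:

Compound 1, `O=C(O)CCC(=O)Nc1cc(Nc2ccc(Cl)cc2)ncn1`: 2730 nM
Compound 2, `COc1cccc(Nc2cc(Nc3cc(OC)ccc3OC)ncn2)c1`: 890 nM
Compound 3, `COc1ccc(Nc2cc(NC(=O)c3ccccc3)ncn2)cc1`: 11400 nM

Of these three, compound 3 gives the highest number, and so is the weakest inhibitor of the set. Its nearest neighbour on the scale is compound 1, whose number is lower by a margin that lies beyond the scatter, and compound 2 lies further still, again well beyond the scatter. Compound 3 is thus clearly the least potent of the three in this assay.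

The next compound, compound 4, `CCOc1ccc(Nc2cc(NC(=O)c3ccccc3)ncn2)cc1`, is not yet measured. It keeps the whole of compound 3 and changes one group at its edge: methyl in place of hydrogen on a saturated chain carbon bound to an oxygen on an aromatic ring. Among the measured compounds shown here, no pair among the three measured compounds differs by a single change, so there is no measured step to lean on here. A change this small, adding a single carbon to a chain hanging off the outer ring, is expected to move the number little, and no shift beyond the scatter is anticipated in either direction.

Compound 4 is therefore expected to give 11000 nM in this assay, with a plausible range from 4500 nM to 27000 nM. The step that this estimate implies, a 1.0-fold lower number from compound 3 to compound 4 (0.02 log units; within the scatter), is expected to stay within the usual scatter.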

Compound 4, half-maximal inhibitory concentration: 7070 nM
Estimate against measurement, compound 4: 1.6-fold (0.19 log units) above, and the stated range covers the measured number.
By their numbers in this assay, from the lowest: compound 2; then compound 1; then compounds 4 and 3 (each within the scatter of the next).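

In this assay, among the compounds shown here, the pair of compound 3 and compound 4 gives the first comparison in this set that differs in one place only, and its step (a 1.6-fold lower number from compound 3 to compound 4 (0.21 log units; within the scatter)) lies within the usual scatter, so the two compounds cannot be told apart. At this place, a saturated chain carbon bound to an oxygen on an aromatic ring, one extra methyl turns methoxy into ethoxy, and with the rest of compound 3 held fixed the assay shows no real difference, which means this position accepts that small addition without a measurable loss. No separate data bear on this result, so the comparison records only what happened and offers no explanation for it.

A single step of one carbon cannot show how much further this position can be extended, and a longer chain such as propoxy or a branched one such as isopropoxy could read quite differently. The same holds for a hydroxyl group or an amine placed at the end of the chain, and for the bare phenol with no chain at all.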